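A few compounds are considered here, and "the series" means these few. Any claim that something is new, unique, unknown or untested is made for them only; others in the source may bear on it.

Compound 1: `CCCCNC(=O)N1C[C@H](O)[C@@H](O)[C@H](O)[C@H]1CO` — 27000 nM
Compound 2: `CCCCNC(=N)N1C[C@H](O)[C@@H](O)[C@H](O)[C@H]1CO` — 15000 nM

In an assay for inhibition of beta-galactosidase (Bos taurus), read by spectrophotometry, with a stated time of 30 min (on this read-out higher numbers stand for weaker inhibition and lower numbers for stronger inhibition), compound 1 gives 27000 nM and compound 2 gives 15000 nM. Compound 2 has the lower of the two numbers, yet its gap to compound 1 lies within the scatter, so the two cannot be ordered. Compound 3, `CCCCCCCCNC(=N)N1C[C@H](O)[C@@H](O)[C@H](O)[C@H]1CO`, differs from compound 2 by butyl in place of hydrogen on a saturated chain carbon, four bonds along the chain from an amine nitrogen. For the measured compounds named here, no measured pair shows this kind of change, so its effect is unknown. The expected step is a 2.5-fold lower number from compound 2 to compound 3 (0.40 log units; beyond the scatter), a moderate move toward a lower number that may not clear the scatter. Compound 3 is estimated at 6000 nM, between 1000 nM and 30000 nM.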

Compound 3, half-maximal inhibitory concentration: 2600 nM
The estimate for compound 3 lay 2.3-fold (0.36 log units) above the measured number, and the stated range covers the measured number.
By their numbers in this assay, from the lowest: compound 3; then compounds 2 and 1 (each within the scatter of the next).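

In this assay, butyl in place of hydrogen gives a 5.8-fold lower number from compound 2 to compound 3 (0.76 log units; beyond the scatter), so the number at this saturated chain carbon responds to added carbon atoms, which compound 1 and compound 2, within the scatter of each other, could not show. No evidence at hand accounts for this step. A single step also gives no trend with chain length. From the compounds shown here alone, whether a longer chain would lower the number further, or an amine or a carboxylic acid in that place would keep the gain, stays open.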